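The source may report more compounds than this note shows. Statements on the series, on what has been measured and on what is new or still open speak of the compounds shown alone.

Three compounds of the series have been run in a functional assay on the whole organism (Tail, strain ICR) with Mus musculus as the target, in the tail flick test, with a stated time of 90 min, at a dose of 25 umol/kg by the oral route; on this read-out lower numbers stand for a weaker effect and higher numbers for a stronger effect at the one dose given. Compound 1 `O=C(CN(c1ncnc2c1ncn2C1CCCCO1)C1CC1)N[C@@H](CO)C(=O)OCc1ccccc1` gives 32.2%, compound 2 `N=C(N)NCCC[C@H](NC(=O)CN(c1nc(Cl)nc2[nH]cnc12)C1CC1)C(=O)OCc1ccccc1` gives 30.4%, and compound 3 `C[C@@H](O)[C@H](NC(=O)CN(c1nc(Cl)nc2[nH]cnc12)C1CC1)C(=O)O` gives 35.9%. Compound 2 lies within the scatter of both others, so on these numbers the three are not told apart.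

Compound 4 `C[C@H](NC(=O)CN(c1nc(Cl)nc2[nH]cnc12)C1CC1)C(=O)OCc1ccccc1` has not yet been measured in this assay. Relative to compound 2 the change is a hydrogen atom in place of a group of 6 heavy atoms (3 carbon, 3 nitrogen; no ring), on a saturated chain carbon, two bonds along the chain from an amide-type nitrogen and a carbonyl carbon. No measured pair in the set isolates a change of this kind, so there is no shown step to lean on. With all three measured values sitting in one band, the expectation is that the step from compound 2 to compound 4 is a number 0.4 percentage points lower from compound 2 to compound 4 (within the scatter), none beyond the scatter. Compound 4 is therefore estimated to give 30% in this assay, with a range from 16% to 44%.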

Compound 4, a percentage reported as activity, at one dose (the size of the read-out at that dose, not a potency): 44.2%
For compound 4 the middle estimate is 14.2 percentage points below the measured one, and the stated range ends below it.
By their numbers in this assay, from the lowest: compounds 2, 1, 3 and 4 (each within the scatter of the next, the first and the last beyond it).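

In this assay, going by these compounds alone, replacing the group of 6 heavy atoms with a hydrogen atom gives a number 13.8 percentage points higher from compound 2 to compound 4 (beyond the scatter), the first single change read beyond the scatter. At the one dose given, this position therefore affects the read-out, and the group of 6 heavy atoms is not required for the effect. Nothing available accounts for the step.

Going by these compounds, only compound 2 and compound 4 speak to this position, so the shape of its response remains open. A primary amine or a carboxylic acid at the end of this chain, or a longer plain carbon chain, would test it further.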